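The compounds below may be only part of what the source reports. "The series", "measured", "known", "first", "only" and "open" are said of these compounds alone.

Compound 1 `C[C@H](c1ccc(-c2cc(F)ccc2-c2nc(=O)o[nH]2)cc1)N(CC1CC1)c1nc2c(C(=O)O)cccc2o1` gives the lowest number of the two measured, with 2.3 nM in a functional assay on CAL1 cells for inhibition of chemerin-like receptor 1 (Homo sapiens), with a stated time of 45 min; on this read-out higher numbers stand for weaker inhibition and lower numbers for stronger inhibition; compound 2 `CCCCN(c1nc2c(C(=O)NS(C)(=O)=O)cccc2o1)[C@H](C)c1ccc(-c2ccccc2-c2nnn[nH]2)cc1` gives 14 nM in this assay, a higher number that lies beyond the scatter. Compound 3 `C[C@H](c1ccc(-c2cc(Cl)ccc2-c2nc(=O)o[nH]2)cc1)N(CC1CC1)c1nc2c(C(=O)O)cccc2o1` has not yet been measured. It differs from compound 1 in one place: chloro in place of fluoro on an aromatic carbon. Going by the values given here, no step between measured compounds covers such a change, so the expectation rests on the change itself: chloro in place of fluoro is expected to shift this assay by no more than the scatter, in either direction. Compound 3 is therefore estimated at 2.5 nM, within 1 nM to 6 nM, an expected step of a 1.1-fold higher number from compound 1 to compound 3 (0.04 log units; within the scatter) that stays within the scatter.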

Compound 3, half-maximal inhibitory concentration: 1.3 nM
Estimate against measurement, compound 3: 1.9-fold (0.28 log units) above; the measured number falls inside the stated range.
By their numbers in this assay, from the lowest: compounds 3 and 1 (each within the scatter of the next); then compound 2.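

In this assay, chloro in place of fluoro on this aromatic carbon, meta to a large group and para to a group of 6 heavy atoms, gives a 1.8-fold lower number from compound 1 to compound 3 (0.25 log units; within the scatter) and so stays within the scatter. Going by these compounds alone, this is the first step read at this position, and it shows that the two halogens cannot be told apart here. No measurement shown bears on why the two compounds read alike.

Still open, going by these compounds, is whether a methoxy or a nitrile on the same carbon would also stay this close to compound 1. Also open, on these data alone, is whether a bromo there would read the same.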